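Butoxy in Place of Benzyl on the Aryl Urea

A few compounds are considered here, and "the series" means these few. Any claim that something is new, unique, unknown or untested is made for them only; others in the source may bear on it.

Measured compounds:
Compound 1 `O=C(Nc1ccc(Cc2ccccc2)cc1)Nc1nn(C(=O)Nc2ccc(Cc3ccccc3)cc2)c2ccccc12`: > 100000 nM
Compound 2 `Nc1nn(C(=O)Nc2ccc(Cc3ccccc3)cc2)c2ccccc12`: 2940 nM
Compound 3 `COc1ccccc1NC(=O)n1nc(N)c2ccccc21`: 39100 nM

In a functional assay on KM12 cells (Homo sapiens) for inhibition, read by sulforhodamine B assay, with a stated time of 48 h (on this read-out lower numbers stand for stronger inhibition of growth and higher numbers for weaker inhibition of growth), compound 2 gives 2940 nM, the lowest of the two numbers shown. Compound 3 gives 39100 nM, a higher number that lies beyond the scatter. For compound 1 the assay reports only a limit, > 100000 nM (the limit of > 100000 nM in this assay, at which 1 of the 3 values shown sits).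

Compound 4 `CCCCOc1ccc(NC(=O)n2nc(N)c3ccccc32)cc1` differs from compound 2 by butoxy in place of benzyl on an aromatic carbon. For the measured compounds named here, with no measured pair differing in one place, the size of this step is unknown. A modest loss of potency, beyond the scatter, is expected: a 2.0-fold higher number from compound 2 to compound 4 (0.31 log units; beyond the scatter). Compound 4 is therefore estimated at 6000 nM, with a range from 1500 nM to 25000 nM.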

Compound 4, concentration for 50% growth inhibition: 11300 nM
Estimate against measurement, compound 4: 1.9-fold (0.27 log units) below; measured number inside the range.
By their numbers in this assay, from the lowest: compound 2; then compound 4; then compound 3. At a limit, above all of these: compound 1.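

In this assay, butoxy in place of benzyl gives a 3.8-fold higher number from compound 2 to compound 4 (0.58 log units; beyond the scatter). The aromatic carbon para to a large group therefore accepts a chain with no ring at a modest cost, although benzyl remains the better of the two groups here. No measurement shown gives a cause for this step. From the compounds shown here alone, it remains open whether the cost follows the lost ring or the entering oxygen, which phenoxy or a pentyl chain at this place could separate. Going by these compounds, how an amine or a carboxylic acid would fare there is also open.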